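Working notes: a side-group swap on the shared core

A few compounds are considered here, and "the series" means these few. Any claim that something is new, unique, unknown or untested is made for them only; others in the source may bear on it.

Compound 1 `Nc1cc(N)c2nc(-c3ccccc3)c(Oc3ccc(Cl)c(Cl)c3)nc2c1` carries a 3,4-dichlorophenoxy group on the shared core. In a functional assay on UO-31 cells (Homo sapiens) for inhibition, read by sulforhodamine B assay, with a stated time of 48 h (a higher number here means a weaker inhibitor of growth, a lower number a stronger inhibitor of growth), compound 1 gives only a limit, < 100000 nM. Compound 2 `CCOC(=O)[C@H](CCC(=O)O)NC(=O)c1ccc(Sc2nc3cc(N)cc(N)c3nc2-c2ccccc2)cc1` likewise gives only a limit in this assay, < 100000 nM. Compound 3 `COc1cc(CNc2nc3cc(N)cc(N)c3nc2-c2ccccc2)cc(OC)c1OC` gives a limit as well in this assay, < 50200 nM. Compound 1 therefore stands at the limit of < 100000 nM in this assay, at which 2 of the 3 values shown sit, while compound 3 stands at the limit of < 50200 nM in this assay, at which 1 of the 3 values shown sits. Among the measured compounds shown here, no finished number exists for any of the three, so no step between measured compounds can be drawn, and compound 1 cannot be placed above or below its neighbours.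

Compound 4 `COc1ccc(Sc2nc3cc(N)cc(N)c3nc2-c2ccccc2)cc1` differs from compound 1 in one place: (4-methoxyphenyl)sulfanyl in place of 3,4-dichlorophenoxy on an aromatic carbon. With limits only on the measured side, no direction can be read off for this change. The step is expected at a step that the limit leaves unreadable from compound 1 to compound 4, nothing beyond the scatter. For compound 4 the expected result in this assay is 30000 nM, within the range 5000 nM to 100000 nM, and most likely once more a limit rather than a finished number.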

Compound 4, concentration for total growth inhibition: < 100000 nM
Compound 4 ended at the assay's limit; the forecaster's own chance of this, stated with the estimate: 65%; the middle value does not contradict the limit.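

Compound 1 and compound 4 both give only a limit in this assay, so no step can be read between them. The compounds shown leave open whether (4-methoxyphenyl)sulfanyl in place of 3,4-dichlorophenoxy on an aromatic carbon shifts growth inhibition at all, and in which direction.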